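Phenyl in place of a hydroxyethyl end on the side chain

This account rests on a few compounds, and the source may have more. Where it says the series, first, only, none or still open, it means among the compounds named here.

Compound 1 `CCCCC[Se]c1nc(N)c2ccccc2n1`: in a functional assay on HT-29 cells (Homo sapiens) for cytotoxicity, read by MTT assay, with a stated time of 72 h (a lower number here means that less compound is tolerated, a higher number that more compound is tolerated), compound 1 gives only the limit > 100000 nM.
Compound 2 `C[Se]c1nc(N)c2ccccc2n1`: in this assay compound 2 gives only the limit > 100000 nM.
Compound 3 `CSc1nc(NCCCCCO)c2ccccc2n1`: in this assay compound 3 gives only the limit > 100000 nM.

Within the data shown here, the single step between measured compounds that differ in one place, a step that the two limits leave unreadable from compound 1 to compound 2, cannot be read, as both of its ends are limits. Compound 3 therefore stands nowhere on a scale of numbers: its value is a limit, and it shares that limit with every other measured compound, as the limit of > 100000 nM in this assay, at which 3 of the 3 values shown sit, records. Compound 4 `CSc1nc(NCCCc2ccccc2)c2ccccc2n1` differs from compound 3 by phenyl in place of 2-hydroxyethyl on a saturated chain carbon, three bonds along the chain from a nitrogen on an aromatic ring. Among the measured compounds shown here, no measured step bears on this change: neither the selenium-bearing chain of compound 1 and compound 2 nor the hydroxy-ended chain of compound 3 has yielded a readable number, so there is no measured precedent for swapping a phenyl for a 2-hydroxyethyl group on this chain. For the measured compounds named here, with every value so far at the limit, compound 4 is expected to land near that limit as well, the estimated step being a number no higher from compound 3 to compound 4 (the limit leaves the size open). Compound 4 is thus estimated at 100000 nM in this assay, within a range from 30000 nM to 300000 nM, with a high chance that only a limit is reported.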

Compound 4, concentration lethal to 50% of the cells: > 100000 nM
Compound 4 was reported as a limit; the forecaster's own chance of this, stated with the estimate: 70%; the middle value sits exactly at the limit.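

In this assay compound 4 gives > 100000 nM, which is a limit and not a number. Compared with compound 3, which also gives only a limit, it yields no step that can be read. The compounds shown leave open how far any of them lies beyond that limit, and whether any change to the shared core would give a readable value: the limit of > 100000 nM in this assay, at which 4 of the 4 values shown sit.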